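Acetyl for allyloxy: a cytotoxicity step expected to stay flat

The source may report more compounds than this note shows. Statements on the series, on what has been measured and on what is new or still open speak of the compounds shown alone.

Of the compounds shown here, three sharing one core have been measured in an ADME assay on PC-3 cells (Homo sapiens) for cytotoxicity, read by WST assay, tested at 100 uM; a lower number here means less inhibition, a higher number more inhibition at the concentration tested (going by the name of the read-out). Compound 1 `Cc1cccc(C(=O)N2CCCC(C(=O)Nc3ccc(Cl)cc3)C2)c1` gives 0% in this assay. Compound 2 `C=CCOc1cccc(NC(=O)C2CCCN(C(=O)c3cc(C(F)(F)F)cc(C(F)(F)F)c3)C2)c1` gives 0% in this assay. Compound 3 `O=C(Nc1cccc(Cc2ccccc2)c1)C1CCCN(C(=O)c2cccc(-c3ccco3)c2)C1` gives 0% in this assay. On these numbers compound 2 stands level with compound 1 and with compound 3 at the digits shown; its nearest neighbour is compound 1 and its furthest is compound 3, and neither gap reaches beyond the usual scatter.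

Compound 4 `CC(=O)c1cccc(NC(=O)C2CCCN(C(=O)c3cc(C(F)(F)F)cc(C(F)(F)F)c3)C2)c1` has not yet been measured in this assay. It differs from compound 2 in one place: acetyl in place of allyloxy on an aromatic carbon. The group that leaves and the group that enters are both small, carry no ring and no charge, and sit on the same aromatic carbon, so the change is modest in size.

Going by the values given here, no step between two measured compounds is available to anchor the move. With compound 1, compound 2 and compound 3 all at the same level, no shift beyond the scatter is expected in either direction, and the step of a number 2 percentage points higher from compound 2 to compound 4 (within the scatter) is estimated to be essentially none. Compound 4 is therefore expected to give about 2% in this assay, with a range from 0% to 15%.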

Compound 4, a percentage reported as inhibition, at one concentration (the size of the read-out at that concentration, not a potency): 0%
Compound 4: the middle estimate sits 2 percentage points above what was measured; measured number inside the range.
By their numbers in this assay, from the lowest: compounds 1, 2, 3 and 4 (each within the scatter of the next).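

In this assay, going by these compounds alone, the replacement of allyloxy by acetyl shows no change at the digits printed from compound 2 to compound 4 (within the scatter) and this is the first step in the set that alters one place only, here an aromatic carbon meta to a large group. The earlier compounds shown here differ from one another in more than one place, so they could say nothing about this position alone, whereas this pair shows that the change from 3-(allyloxy)phenyl to 3-acetylphenyl leaves the read-out level at the concentration tested. No measurement at hand bears on why the two compounds read alike.

From the compounds shown here alone, whether an amine or a carboxylic acid on this same aromatic carbon would move the read-out in this assay remains open. So does whether the same swap would read alike on compound 1 or compound 3, which carry other groups elsewhere on the shared core.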